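Chain homologation on the phenyl-bearing analogue

A few compounds are considered here, and "the series" means these few. Any claim that something is new, unique, unknown or untested is made for them only; others in the source may bear on it.

Measured compounds in this series:
compound 1 `N#C/N=C1\N(CCCCCCCOc2ccc(Cl)cc2)C(=O)CN1c1ccncc1` — 3340 nM
compound 2 `CCC1C(=O)N(CCCCCCCOc2ccc(Cl)cc2)/C(=N\C#N)N1c1ccncc1` — 3530 nM
compound 3 `N#C/N=C1\N(CCCCCCOc2ccc(Cl)cc2)C(=O)C(c2ccccc2)N1c1ccncc1` — 37 nM

In a functional assay on DLD-1 cells (Homo sapiens) for cytotoxicity (on this read-out lower numbers stand for stronger inhibition and higher numbers for weaker inhibition), compound 3 gives 37 nM, the lowest of the three numbers and the only one beyond the scatter from both others. Compound 1 gives 3340 nM and compound 2 gives 3530 nM. The step to compound 4 `N#C/N=C1\N(CCCCCCCOc2ccc(Cl)cc2)C(=O)C(c2ccccc2)N1c1ccncc1` is (4-chlorophenoxy)methyl in place of 4-chlorophenoxy on a saturated chain carbon, six bonds along the chain from an amide-type nitrogen in a ring. Within the data shown here, the one single-point step recorded, a 1.1-fold higher number from compound 1 to compound 2 (0.02 log units; within the scatter), concerns the ring carbon and not the chain, so it bears on the present change only by showing that a small edit elsewhere left the number unchanged. Compound 1 and compound 3 differ both in chain length and in the ring substituent, so their two values cannot be split into a chain contribution. The expectation for a 1.4-fold higher number from compound 3 to compound 4 (0.13 log units; within the scatter) is therefore a step of no more than the scatter, in no firm direction. Compound 4 is estimated at 50 nM, with a range from 15 nM to 200 nM in this assay.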

Compound 4, half-maximal inhibitory concentration: 290 nM
For compound 4 the middle estimate is 5.8-fold (0.76 log units) below the measured one; measured number above the stated range.
By their numbers in this assay, from the lowest: compound 3; then compound 4; then compounds 1 and 2 (each within the scatter of the next).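

In this assay, the chain position proves sensitive on the phenyl-bearing core, where the change to (4-chlorophenoxy)methyl gives a 7.8-fold higher number from compound 3 to compound 4 (0.89 log units; beyond the scatter) and so separates chain length from the ring substituent. With the longer chain held constant, phenyl on the saturated ring carbon gives a 12-fold lower number from compound 1 to compound 4 (1.06 log units; beyond the scatter) against hydrogen and a 12-fold lower number from compound 2 to compound 4 (1.09 log units; beyond the scatter) against ethyl, whereas ethyl in place of hydrogen stayed within the scatter. Nothing available accounts for either the chain or the ring-carbon effect.

On these data alone, only these chain lengths appear on the phenyl-bearing core, so it remains open whether 4-(4-chlorophenoxy)butyl or a shorter chain would continue the same direction. As far as these compounds go, whether benzyl or cyclohexyl on the ring carbon would match the gain seen with phenyl also remains open.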